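The source may hold more compounds than are shown below. What is called first, only, known or untested is meant among the compounds shown, and "the series" means these compounds.

Working notes on the series.

Compound 1 `CCc1nc(-c2cnc3ccc(-c4ccc(OC)cc4)cc3c2)no1` and compound 2 `CCc1nc(-c2cnc3ccc(-c4ccc(F)cc4)cc3c2)no1` share one core and differ only at a single aromatic carbon. In a functional assay on RD cells (Homo sapiens) for inhibition, read by luminescence and ATP content, with a stated time of 72 h (a higher number here means that more compound is tolerated, a lower number that less compound is tolerated), compound 1 gives > 2500 nM, which is a limit of the assay and not a number. In this assay compound 2 gives > 7400 nM, again a limit rather than a number. The step that the two limits leave unreadable from compound 1 to compound 2 is therefore not readable in size; both values sit at limits, as recorded in the limit of > 2500 nM in this assay, at which 1 of the 2 values shown sits, and (the limit of > 7400 nM in this assay, at which 1 of the 2 values shown sits). Compound 2 thus stands at the high end of what the assay can report, with no number of its own.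

Compound 3 `CCc1nc(-c2cnc3ccc(-c4ccc(N)c(Cl)c4)cc3c2)no1` is not yet measured in this assay. The change from compound 2 is 4-amino-3-chlorophenyl in place of 4-fluorophenyl on an aromatic carbon. Within the data shown here, no measured step bears directly on this exchange; the only measured step is the unreadable one from compound 1 to compound 2. With both neighbours at limits, the expected step is a number no higher from compound 2 to compound 3 (the limit leaves the size open), meaning no change beyond the scatter can be claimed. Compound 3 is estimated at 7400 nM, in the range 2500 nM to 25000 nM, with a limit the most likely outcome.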

Compound 3, half-maximal cytotoxic concentration: > 7400 nM
Compound 3 ended at the assay's limit (the forecaster's own chance of this, stated with the estimate: 70%); the middle value lies on the limit itself.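

In this assay, among these compounds, compound 1, compound 2 and compound 3 all sit at limits and not at numbers, so no step among them can be read in size, including those to compound 3. The compounds shown leave open where each half-maximal cytotoxic concentration lies, and whether exchanging 4-methoxyphenyl, 4-fluorophenyl and 4-amino-3-chlorophenyl changes it at all.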